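The source may hold more compounds than are shown below. What is called first, only, known or untested is meant among the compounds shown, and "the series" means these compounds.

Compound 1 `CCCN(CC[C@H]1CC[C@H](NC(=O)/C=C/c2ccccc2Cl)CC1)[C@H]1CCc2nc(N)sc2C1` gives 1.2 nM in an assay on brain for displacement of a labelled ligand from D(3) dopamine receptor (Rattus norvegicus); on this read-out lower numbers stand for stronger inhibition and higher numbers for weaker inhibition.
Compound 2 `CCCN(CC[C@H]1CC[C@H](NC(=O)c2ccc(-n3ccnc3)cc2)CC1)[C@H]1CCc2nc(N)sc2C1` gives 1.9 nM in this assay.

For the measured compounds named here, these two numbers sit close together: the step of a 1.6-fold higher number from compound 1 to compound 2 (0.20 log units; within the scatter) shows that compound 2 and compound 1 cannot be told apart on this read-out, so compound 2 stands level with the only other measured compound.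

Compound 3 `CCCN(CC[C@H]1CC[C@H](NC(=O)c2ccc(-c3noc(C4CC4)n3)cc2)CC1)[C@H]1CCc2nc(N)sc2C1` has not yet been measured. It differs from compound 2 by 5-cyclopropyl-1,2,4-oxadiazol-3-yl in place of 1H-imidazol-1-yl on an aromatic carbon of a six-membered aromatic ring of carbon only, para to a large group.

Going by the values given here, the only step with numbers, a 1.6-fold higher number from compound 1 to compound 2 (0.20 log units; within the scatter), exchanged the whole group on the carbonyl carbon and stayed within the scatter, so a sweeping change at that end of the molecule hardly moved the number. The change to compound 3 is narrower in kind, swapping one five-membered aromatic ring for another on the same six-membered ring. No step beyond the scatter is therefore expected in this assay, in either direction. Compound 3 is expected to give about 2 nM, between 0.7 nM and 6 nM. That amounts to an expected 1.1-fold higher number from compound 2 to compound 3 (0.02 log units; within the scatter).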

Compound 3, inhibition constant: 3.5 nM
Compound 3: the middle estimate sits 1.8-fold (0.24 log units) below what was measured; low and high end bracket the measured number.
By their numbers in this assay, from the lowest: compounds 1, 2 and 3 (each within the scatter of the next, the first and the last beyond it).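

In this assay, the change on the six-membered aromatic ring gives a 1.8-fold higher number from compound 2 to compound 3 (0.27 log units; within the scatter), even though 5-cyclopropyl-1,2,4-oxadiazol-3-yl brings 8 heavy atoms in place of the 5 of 1H-imidazol-1-yl, along with an oxygen and a three-membered ring of carbon. The earlier step replaced the whole group on the carbonyl carbon, whereas this one keeps the six-membered aromatic ring and alters only what is attached para to a large group, showing that this narrower exchange also cannot be told apart on this read-out. No supporting data are available to explain why the number holds across this exchange.

From the compounds shown here alone, compound 2 and compound 3 both carry a five-membered aromatic ring at this position, so it remains open whether the number would hold with a primary amine, a carboxylic acid or a longer alkyl chain there. Going by these compounds, the separate contribution of the cyclopropyl group also remains open, as does whether a methyl group in its place on the 1,2,4-oxadiazole ring would give a similar number.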